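From methylcarbamoyl to 1H-pyrazol-4-yl: a clearance estimate

The compounds below may be only part of what the source reports. "The series", "measured", "known", "first", "only" and "open" are said of these compounds alone.

Measured so far in an ADME assay on microsomes from liver (Rattus norvegicus, strain Sprague-Dawley) for pharmacokinetics, read by LC-MS, using NADPH, with a stated time of 45 min, tested at 1 uM; on this read-out higher numbers stand for fast clearance and lower numbers for slow clearance:
Compound 1 `Nc1nccc(COc2cc(Cl)c3nc(N[C@@H]4CCCC[C@H]4O)sc3c2)c1Cl` gives 78 mL/min/kg
Compound 2 `CNC(=O)Nc1nccc(COc2cc(OC)c3nc(N[C@H]4CCCC[C@@H]4O)sc3c2)n1` gives 19 mL/min/kg

Compound 2 has the lower of these two numbers, and the gap to compound 1 lies beyond the scatter. Compound 3 `COc1cc(OCc2ccnc(Nc3cn[nH]c3)n2)cc2sc(N[C@H]3CCCC[C@@H]3O)nc12` is not yet measured and differs from compound 2 by 1H-pyrazol-4-yl in place of methylcarbamoyl on a nitrogen on an aromatic ring. For the measured compounds named here, no measured pair shows this change. In this assay the expected move is a 1.8-fold higher number from compound 2 to compound 3 (0.27 log units; within the scatter) (a modest rise toward faster clearance, near the edge of the scatter). This expectation starts from compound 2 at 19 mL/min/kg and stays under compound 1 at 78 mL/min/kg (the higher value). For compound 3 the estimated clearance is 35 mL/min/kg with 15 mL/min/kg to 80 mL/min/kg as its expected range.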

Compound 3, clearance: 120 mL/min/kg
For compound 3 the middle estimate is 3.4-fold (0.54 log units) below the measured one; the whole stated range lies below it.
By their numbers in this assay, from the lowest: compound 2; then compounds 1 and 3 (each within the scatter of the next).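

On a nitrogen on an aromatic ring, 1H-pyrazol-4-yl in place of methylcarbamoyl gives a 6.3-fold higher number from compound 2 to compound 3 (0.80 log units; beyond the scatter) in this assay and so shows that this one group can move clearance beyond the scatter. Both groups count one hydrogen-bond donor and one acceptor, so these counts do not separate the two results. Nothing available here bears on why the number rises.

Still open, as far as these compounds go, is where a smaller acetyl group or a phenyl ring on that nitrogen would fall. Also open, from the compounds shown here alone, is whether an N-methylated pyrazole would behave like 1H-pyrazol-4-yl.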